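The compounds below may be only part of what the source reports. "The series", "measured", "known", "first", "only" and "open" are said of these compounds alone.

In a functional assay on A549 cells (Homo sapiens) for cytotoxicity, read by sulforhodamine B assay, with a stated time of 48 h (a higher number here means a weaker inhibitor, a lower number a stronger inhibitor), compound 1 `COc1ccc(/C=C/C(=O)c2cccc(Br)c2)cc1OC` gives 9430 nM. Compound 2 `COc1ccc(/C=C/C(=O)c2cccc(-c3cccc(F)c3)c2)cc1OC` has the lower number of the two, at 1940 nM. Compound 3 `COc1ccc(/C=C/C(=O)c2cccc(-c3ccc(F)cc3)c2)cc1OC` carries 4-fluorophenyl in place of 3-fluorophenyl on an aromatic carbon. Among the measured compounds shown here, the only measured step, a 4.9-fold lower number from compound 1 to compound 2 (0.69 log units; beyond the scatter), puts 3-fluorophenyl in place of bromo. For the measured compounds named here, it is a modest step, and no measured pair compares the two fluorophenyl groups, so no change beyond the scatter is expected in this assay. The expected step is a 1.0-fold lower number from compound 2 to compound 3 (0.01 log units; within the scatter). For compound 3 the estimated value is 1900 nM, with an expected range of 850 nM to 4200 nM.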

Compound 3, half-maximal inhibitory concentration: 11800 nM
For compound 3 the middle estimate is 6.2-fold (0.79 log units) below the measured one; measured number above the stated range.
By their numbers in this assay, from the lowest: compound 2; then compounds 1 and 3 (each within the scatter of the next).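

In this assay, the place of the fluorine on the ring matters at this position: the two fluorophenyl groups have the same atoms, yet the change gives a 6.1-fold higher number from compound 2 to compound 3 (0.78 log units; beyond the scatter). The step away from bromo therefore does not carry over to every fluorophenyl group, as a 1.3-fold higher number from compound 1 to compound 3 (0.10 log units; within the scatter) does not separate 4-fluorophenyl from bromo. Nothing available explains this difference between the two fluorophenyl groups. As far as these compounds go, it remains open whether an unsubstituted phenyl or a methoxyphenyl on this carbon would fall with compound 2 or with compound 3.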